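Replacing a phenoxy group with an aminopyrrolidine amide

The source may report more compounds than this note shows. Statements on the series, on what has been measured and on what is new or still open speak of the compounds shown alone.

The series shares one core, shown in compound 1 `NCc1cc(Oc2cccc(C(=O)NCCS(N)(=O)=O)c2)nc(C(F)(F)F)c1`, compound 2 `NCc1cc(O[C@@H]2CCCN(C(=O)Nc3ccccc3)C2)nc(C(F)(F)F)c1` and compound 3 `NCc1cc(Oc2cccc(Oc3ccccc3)c2)nc(C(F)(F)F)c1`. Exposure was followed in an ADME assay on the whole organism (lung, Mus musculus) for pharmacokinetics, read by LC-MS, at a dose of 30 mg/kg by the oral route; a lower number here means less compound in the circulation, a higher number more compound in the circulation at the dose given. In this assay compound 1 gives 540 nM. In this assay compound 2 gives "not determined" (no result reported), and compound 3 gives "not determined" (no result reported), so only compound 1 offers a measured point of reference.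

Compound 4 `NCc1cc(Oc2cccc(C(=O)N3CC[C@@H](N)C3)c2)nc(C(F)(F)F)c1` differs from compound 3 at a single position: (3-aminopyrrolidin-1-yl)carbonyl in place of phenoxy on an aromatic carbon. With no number for compound 3, the size and direction of the step between compound 3 and compound 4 cannot be drawn from the data, and the expectation for compound 4 rests on the whole-series picture alone.

Compound 4 carries, like compound 1, an amide in place of the second ring of compound 3, and compound 1 gives 540 nM, so exposure of the same order is expected for compound 4. The maximal plasma concentration of compound 4 in this assay is therefore estimated at 400 nM, with a plausible range from 100 nM to 1500 nM.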

Compound 4, maximal plasma concentration: 1230 nM
Estimate against measurement, compound 4: 3.1-fold (0.49 log units) below; low and high end bracket the measured number.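

In this assay, among these compounds, 3-aminopyrrolidin-1-yl in place of (2-sulfamoylethyl)amino on the carbonyl carbon gives a 2.3-fold higher number from compound 1 to compound 4 (0.36 log units; beyond the scatter), the first reading of how the group on this carbonyl bears on the amount of compound in the circulation after an oral dose. The step is modest but beyond the scatter, so with the shared core and the carbonyl kept in place, the group attached to that carbonyl is a point at which the maximal plasma concentration can shift, and the cyclic amide with its defined stereocentre gives the higher number of the pair. Nothing reported with these compounds accounts for the step, which therefore stands as an observation without an explanation.

Going by these compounds, the steps that lead from compound 2 or compound 3 to any other compound cannot be read, so the effect of phenoxy against an amide at this position remains unknown. On these data alone, it also remains open whether the higher number depends on the ring amine of compound 4, which a plain pyrrolidin-1-yl, a piperidin-1-yl or a 3-hydroxypyrrolidin-1-yl on the same carbonyl would help to settle.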